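A Chlorophenyl in Place of a Methoxyphenyl: Expected Potency

This account rests on a few compounds, and the source may have more. Where it says the series, first, only, none or still open, it means among the compounds named here.

Of the compounds shown here, three sharing one core have been tested in a functional assay on BGC-823 cells (Homo sapiens) for cytotoxicity, read by MTT assay; a lower number here means a stronger inhibitor, a higher number a weaker inhibitor. Compound 1 `COc1cccc(/C=C/C(=O)c2sc(Nc3ccc(Cl)c(Cl)c3)nc2C)c1` is the only one of the three to return a number, giving 8350 nM. Compound 2 `Cc1ccc(Nc2nc(C)c(C(=O)/C=C/c3ccccc3)s2)cc1` reaches only the limit of the assay, > 25000 nM. Compound 3 `COc1cc(/C=C/C(=O)c2sc(Nc3ccc(Cl)c(Cl)c3)nc2C)cc(OC)c1OC` likewise stops at the limit, > 25000 nM. So compound 1 stands alone with a measured value, while the other two sit at the limit of > 25000 nM in this assay, at which 2 of the 3 values shown sit, and compound 1 is therefore the single point of reference.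

Compound 4 `Cc1nc(Nc2ccc(Cl)c(Cl)c2)sc1C(=O)/C=C/c1ccc(Cl)cc1` has not yet been measured. It differs from compound 1 in one place: 4-chlorophenyl in place of 3-methoxyphenyl on a double-bonded chain carbon bound to a double-bonded chain carbon. Among the measured compounds shown here, no pair of measured compounds differs in exactly one place, so there is no measured step to lean on for the direction of this change. In this assay the change is expected to shift the value only modestly, within or close to the ordinary scatter, with no firm direction. The value expected for compound 4 is 7000 nM, with a range from 2500 nM to 25000 nM. The step this estimate implies, a 1.2-fold lower number from compound 1 to compound 4 (0.08 log units; within the scatter), is expected to be small. Two of the three known values are limits, and a limit for compound 4 also remains possible.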

Compound 4, half-maximal inhibitory concentration: 22700 nM
Estimate against measurement, compound 4: 3.2-fold (0.51 log units) below; the measured number falls inside the stated range.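

Among the compounds shown here, this is the first measured step in the set: 4-chlorophenyl in place of 3-methoxyphenyl on a double-bonded chain carbon bound to a double-bonded chain carbon gives a 2.7-fold higher number from compound 1 to compound 4 (0.43 log units; beyond the scatter) in this assay. The place is therefore not indifferent to what it carries, and this change leads to a weaker inhibitor even though both groups are a six-membered aromatic ring of carbon only. Little room remains in this direction, as the value of compound 4 already lies close to the ceiling of the test, where other compounds in the set stop: the limit of > 25000 nM in this assay, at which 2 of the 4 values shown sit.

The step changes two things at once, the group on the ring and its number in the name, and the compounds shown do not separate the effect of one from the other. From the compounds shown here alone, how a phenyl ring bearing an amine or a carboxylic acid would read at this place also stays open, as does whether any group here can give a lower number than the 3-methoxyphenyl of compound 1.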